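Mirror-image step from compound 2 to compound 3

The source may report more compounds than this note shows. Statements on the series, on what has been measured and on what is new or still open speak of the compounds shown alone.

Measured so far in a functional assay on L1210 cells (Mus musculus) for cytotoxicity; a higher number here means a weaker inhibitor, a lower number a stronger inhibitor
- compound 1 `CCCCCCCCCCCCCC[C@@H]1N[C@H](CO)[C@H]1O` gives 4.5 ug/mL
- compound 2 `CCCCCCCCCCCCCC[C@H]1N[C@@H](CO)[C@H]1O` gives > 10 ug/mL

For compound 2 the reading of > 10 ug/mL is a limit and not a number, so its place on the scale is not fixed.

The change to compound 3 `CCCCCCCCCCCCCC[C@@H]1N[C@H](CO)[C@@H]1O` is the two compounds have the same atoms and bonds and differ only in configuration as drawn: 3 of 3 stereo elements differ (all stereocentres are inverted: mirror images); a stereocentre at a saturated ring carbon is drawn R in compound 2 and S in compound 3; a stereocentre at a saturated ring carbon is drawn S in compound 2 and R in compound 3; a stereocentre at a saturated ring carbon is drawn S in compound 2 and R in compound 3. Nothing leaves and nothing enters, and compound 3 is the mirror image of compound 2.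

Within the data shown here, the one measured step that bears on this is an at least 2.2-fold higher number from compound 1 to compound 2 (0.34 log units; beyond the scatter), which lies beyond the scatter and is at least modest. It goes with the fact that compounds 1 and 2 differ only in the configuration as drawn. Configuration alone can therefore move the read-out in this assay in this series, though a single pair is thin support. Compound 1 gives 4.5 ug/mL, so a numeric reading is attainable among these stereoisomers. A step to a lower number, meaning a stronger inhibitor, is expected on inverting every stereocentre, with a real chance of no measurable gain.

The estimated step is an at least 1.6-fold lower number from compound 2 to compound 3 (0.22 log units; that floor lies within the scatter).

For compound 3 the expected value is 6 ug/mL, with an estimated range of 2.5 ug/mL to 14 ug/mL.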

Compound 3, half-maximal inhibitory concentration: 7.5 ug/mL
Estimate against measurement, compound 3: 1.3-fold (0.10 log units) below, within the range that was stated.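

In this assay, inverting every stereocentre gives an at least 1.3-fold lower number from compound 2 to compound 3 (0.12 log units; that floor lies within the scatter), so a numeric reading appears on one side of the mirror-image pair, but that floor does not clear the scatter and compound 2 carries only a limit, which leaves the size of the step unfixed. The change at a single stereocentre, drawn S in compound 1 and R in compound 3, gives a 1.7-fold higher number from compound 1 to compound 3 (0.22 log units; within the scatter), so that stereocentre has no effect that can be read in this assay, while the change at two stereocentres gave an at least 2.2-fold higher number from compound 1 to compound 2 (0.34 log units; beyond the scatter). A numeric reading is therefore not confined to compound 1, and the one step beyond the scatter is the one that ends at the limit of compound 2, with configuration the only thing that separates these compounds: the fact that compounds 1 and 3 differ only in the configuration as drawn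

From the compounds shown here alone, the true reading of compound 2 stays open, and with it the real size of both steps that end or start there. Also open, going by these compounds, is whether the readings of compound 1 and compound 3 would hold with a shorter chain or with a carboxylic acid on the shared core.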